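Repeating a Chloro Step on a Different Pyridine Core

This account rests on a few compounds, and the source may have more. Where it says the series, first, only, none or still open, it means among the compounds named here.

Compound 1 `O=S(=O)(/C=C/c1ccccn1)c1ccccc1F` was tested in an assay on U2OS cells for activation of nuclear factor erythroid 2-related factor 2 (Homo sapiens), read by beta-arrestin recruitment, with a stated time of 6 h (on this read-out higher numbers stand for an effect only at larger amounts of compound and lower numbers for an effect already at smaller amounts), and compound 1 gives 1050 nM. Compound 2 `O=S(=O)(/C=C/c1ncccc1Cl)c1ccccc1F` differs by chloro in place of hydrogen on an aromatic carbon and in this assay compound 2 gives 30 nM; this change made a 35-fold lower number from compound 1 to compound 2 (1.54 log units; beyond the scatter). Compound 3 `O=S(=O)(/C=C/c1cccnc1)c1cccc(Cl)c1` gives 3520 nM in this assay; the difference between the cores of compound 1 and compound 3 is not broken down here. Compound 4 `O=S(=O)(/C=C/c1ccc(Cl)nc1)c1cccc(Cl)c1` is unmeasured and differs from compound 3 by chloro in place of hydrogen on an aromatic carbon. This is the same kind of change as from compound 1 to compound 2, but not the same: here the chloro is next to the ring nitrogen and para to a large group, rather than ortho to a large group and two atoms from the ring nitrogen, and the core differs. For the measured compounds named here, a smaller step is expected, a 3.9-fold lower number from compound 3 to compound 4 (0.59 log units; beyond the scatter), since the only comparable change gave a 35-fold lower number from compound 1 to compound 2 (1.54 log units; beyond the scatter) at a different place. Compound 4 is estimated to give 900 nM in this assay, expected between 250 nM and 3500 nM.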

Compound 4, half-maximal effective concentration: 2210 nM
Compound 4: middle estimate off by 2.5-fold (0.39 log units), on the low side, within the range that was stated.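

In this assay, chloro in place of hydrogen on an aromatic carbon gives a 1.6-fold lower number from compound 3 to compound 4 (0.20 log units; within the scatter), so the large step seen on the core of compound 1 does not carry over to the core of compound 3, and the two steps differ: the same change on two cores in this assay, a 35-fold lower number (1.54 log units; beyond the scatter) from compound 1 to compound 2 and a 1.6-fold lower number (0.20 log units; within the scatter) from compound 3 to compound 4, 22-fold (1.34 log units) apart, beyond the scatter of two such steps. In this series, then, the change is not worth a fixed amount. The place of the chloro and the core both differ between the two pairs, so these compounds cannot show which of the two sets the size of the step.

As far as these compounds go, it remains open whether chloro at the place it holds in compound 2 would give a large step on the core of compound 3. Also open, from the compounds shown here alone, is how an amine or a methoxy group would compare with chloro at either place.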